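Moving the bromo group on the phenyl of compound 3

The source may report more compounds than this note shows. Statements on the series, on what has been measured and on what is new or still open speak of the compounds shown alone.

In a functional assay (muscle tissue) with Cavia porcellus as the target (on this read-out higher numbers stand for an effect only at larger amounts of compound and lower numbers for an effect already at smaller amounts), compound 3 (`COC(=O)C1=C(C)N=C(C)/C(=C(\O)OC)C1c1ccccc1Br`) gives 7.59 nM, the lowest of three numbers, against compound 2 (`COC(=O)C1=C(C)N=C(C)/C(=C(\O)OC)C1c1ccccc1C#N`) at 15.9 nM and compound 1 (`COC(=O)C1=C(C)N=C(C)/C(=C(\O)OC)C1c1ccc(F)cc1`) at 129 nM. Compound 4 (`COC(=O)C1=C(C)N=C(C)/C(=C(\O)OC)C1c1ccc(Br)cc1`) has 4-bromophenyl in place of 2-bromophenyl on a saturated ring carbon. Within the data shown here, no measured step tests this change directly. The nearest evidence is a 17-fold lower number from compound 1 to compound 3 (1.23 log units; beyond the scatter), a large step, and an 8.1-fold lower number from compound 1 to compound 2 (0.91 log units; beyond the scatter), a modest one; both replace 4-fluorophenyl. The step of a 2.1-fold lower number from compound 2 to compound 3 (0.32 log units; beyond the scatter) is small beside them. A large step to a higher number is therefore expected in this assay. The expected step is an 18-fold higher number from compound 3 to compound 4 (1.27 log units; beyond the scatter). Compound 4 is estimated at 140 nM, with an expected range of 40 nM to 500 nM.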

Compound 4, half-maximal effective concentration: 540 nM
The estimate for compound 4 lay 3.9-fold (0.59 log units) below the measured number; the measured number lies above the stated range.
By their numbers in this assay, from the lowest: compound 3; then compound 2; then compound 1; then compound 4.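

In this assay, among these compounds, moving the bromo group alone gives a 71-fold higher number from compound 3 to compound 4 (1.85 log units; beyond the scatter) with the same atoms joined differently, so this position on the phenyl matters more than the earlier steps showed. The 4-bromophenyl also compares poorly with the 2-cyanophenyl, at a 34-fold higher number from compound 2 to compound 4 (1.53 log units; beyond the scatter) and, with the ring position held, bromo in place of fluoro gives a 4.2-fold higher number from compound 1 to compound 4 (0.62 log units; beyond the scatter) in the same direction. No measurement on hand explains these steps.

Open, going by these compounds, is whether an amine or a methoxy group on the phenyl would follow the same course. Also open, on these data alone, is how a longer chain in place of the methoxycarbonyl group would behave with the 2-bromophenyl in place.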